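The source may hold more compounds than are shown below. What is called first, only, known or untested is meant among the compounds shown, and "the series" means these compounds.

Within the data shown here, compound 1 `O=C1NCCN(c2cccc(Cl)c2)N1` gives 5300 nM in an assay on RBL-1 cells for inhibition of Polyunsaturated fatty acid 5-lipoxygenase (Rattus norvegicus) (on this read-out lower numbers stand for stronger inhibition and higher numbers for weaker inhibition), the second highest of the three numbers so far. Compound 2 `CC1CN(c2cccc(Cl)c2)NC(=O)N1` gives 2700 nM in this assay, and the step of a 2.0-fold lower number from compound 1 to compound 2 (0.29 log units; within the scatter) is within the scatter. Among the measured compounds shown here, compound 3 `O=C1NCCN(c2cnc3ccccc3c2)N1` gives 32000 nM in this assay, a higher number than compound 1 and beyond the scatter; no single-point step connects the two. Compound 4 `O=C1NCCN(c2cccc(-c3nccs3)c2)N1` differs from compound 1 by 1,3-thiazol-2-yl in place of chloro on an aromatic carbon, on an aromatic carbon of a six-membered aromatic ring of carbon only, meta to a group of 7 heavy atoms. For the measured compounds named here, the only measured step, from compound 1 to compound 2, concerns a saturated ring carbon and does not bear on this change; no measured step covers a substituent on this aromatic ring. For compound 4 the expected step is a 1.3-fold lower number from compound 1 to compound 4 (0.12 log units; within the scatter), with a wide range. The estimate for compound 4 in this assay is 4000 nM, between 1000 nM and 16000 nM.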

Compound 4, half-maximal inhibitory concentration: 35000 nM
Compound 4: the middle estimate sits 8.8-fold (0.94 log units) below what was measured, outside the stated range (above it).
By their numbers in this assay, from the lowest: compounds 2 and 1 (each within the scatter of the next); then compounds 3 and 4 (each within the scatter of the next).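

Among these compounds, this is the first reading on a substituent of this aromatic ring: in this assay, 1,3-thiazol-2-yl in place of chloro gives a 6.6-fold higher number from compound 1 to compound 4 (0.82 log units; beyond the scatter), a step beyond the scatter, where higher numbers mean weaker inhibition. The position therefore responds to what it carries, although this rests on a single pair. Nothing at hand explains the step.

With only chloro and 1,3-thiazol-2-yl shown here, it remains open how a methoxy group, an amine or a carboxylic acid on this carbon would read. A phenyl ring on this carbon would also show whether the step follows any aromatic ring or this one alone.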